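Chloro on the benzoyl ring of a sulfonamide series

This account rests on a few compounds, and the source may have more. Where it says the series, first, only, none or still open, it means among the compounds named here.

Compound 1 `Cc1ccc(S(=O)(=O)NCc2ccc(CNC(=O)c3ccccc3)cc2)cc1` carries a methyl on the sulfonyl-bearing ring and an unsubstituted benzoyl. In an assay on MDA-MB-231 cells for binding affinity to C-X-C chemokine receptor type 4 (Homo sapiens), read by immunofluorescence and microscopy, with stated times of 10 min and 30 min (a higher number here means that more compound is needed for the effect, a lower number that less compound is needed), compound 1 gives > 1000 nM, which is a limit of the assay rather than a number (the limit of > 1000 nM in this assay, at which 1 of the 3 values shown sits). Compound 2 `Cc1ccc(S(=O)(=O)NCc2ccc(CNC(=O)c3cccc(Cl)c3)cc2)cc1` differs from compound 1 by chloro in place of hydrogen on an aromatic carbon and in this assay compound 2 gives 100 nM, a step of an at least 10-fold lower number from compound 1 to compound 2 (1.00 log units; beyond the scatter). Among the compounds with values here, compound 3 `O=C(NCc1ccc(CNS(=O)(=O)c2ccccc2)cc1)c1ccccc1` differs from compound 1 by hydrogen in place of methyl on an aromatic carbon and in this assay compound 3 gives 1 nM, a step of an at least 1000-fold lower number from compound 1 to compound 3 (3.00 log units; beyond the scatter); against compound 2 it stands lower only in the sense told by the two values themselves, no further step being worked out here.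

Compound 4 `O=C(NCc1ccc(CNS(=O)(=O)c2ccccc2)cc1)c1ccccc1Cl` is not yet measured. It differs from compound 3 by chloro in place of hydrogen on an aromatic carbon. Within the data shown here, this is the same kind of change as the one from compound 1 to compound 2, made twice in all across the set, but not the same: in compound 2 the chloro sits meta to a large group, in compound 4 ortho to a large group, and the cores differ as set out above. The earlier step rests on a starting value that is only a limit, so its true size is open. Compound 3 already sits at the low end, so a smaller gain is expected, about a 1.7-fold lower number from compound 3 to compound 4 (0.22 log units; within the scatter) in this assay. Compound 4 is therefore estimated at 0.6 nM in this assay, within 0.1 nM to 4 nM.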

Compound 4, effective concentration (reported as EC, without a stated level of effect): 10 nM
Beside the measured number, compound 4's estimate is 17-fold (1.22 log units) below it; the whole stated range lies below it.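

In this assay, chloro in place of hydrogen on the benzoyl ring gives a 10-fold higher number from compound 3 to compound 4 (1.00 log units; beyond the scatter), so on the core of compound 3 the change does not repeat the lower number seen on the core of compound 1, and the two steps run in opposite directions: the same change on two cores in this assay, an at least 10-fold lower number (1.00 log units; beyond the scatter) from compound 1 to compound 2 and a 10-fold higher number (1.00 log units; beyond the scatter) from compound 3 to compound 4, at least 100-fold (2.00 log units) apart, beyond the scatter of two such steps. This shows that the sign of the step does not transfer between these two cores as the pairs stand, but it does not show that the core alone sets the outcome, as the chloro in compound 4 sits ortho to a large group and the chloro in compound 2 sits at a different place on the ring, so core and position change together between the two steps. As far as these compounds go, compound 1 gives > 1000 nM, which is a limit and not a number, so the size of the earlier step stays open, though not its direction: the limit of > 1000 nM in this assay, at which 1 of the 4 values shown sits.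

Still open, from the compounds shown here alone, is whether chloro at one and the same place on both cores would step the same way. Also open, going by these compounds, is how a methoxy group, an amine or a carboxylic acid on the benzoyl ring, or a longer chain in place of the methyl on the sulfonyl-bearing ring, would read in this assay.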